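The source may hold more compounds than are shown below. What is called first, only, known or untested is meant among the compounds shown, and "the series" means these compounds.

Compound 1 `CC1(C)[C@H]2CC[C@]1(C)N(Cc1cn(-c3cccc(C#N)c3)nn1)C(=O)C2`: 40 nM
Compound 2 `CC1(C)[C@H]2CC[C@]1(C)N(Cc1cn(-c3ccccc3F)nn1)C(=O)C2`: 60 nM
Compound 3 `CC1(C)[C@H]2CC[C@]1(C)N(Cc1cn(-c3ccccc3)nn1)C(=O)C2`: 90 nM

These values come from a functional assay on HepG2 cells (Homo sapiens) for inhibition, read by MTT assay, with a stated time of 24 h; a lower number here means a stronger inhibitor, a higher number a weaker inhibitor. Compound 2 cannot be told apart from either of the other two compounds on these numbers. Its two steps are a 1.5-fold higher number from compound 1 to compound 2 (0.18 log units; within the scatter) and a 1.5-fold higher number from compound 2 to compound 3 (0.18 log units; within the scatter).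

Compound 4 `Cc1ccc(-n2cc(CN3C(=O)C[C@@H]4CC[C@@]3(C)C4(C)C)nn2)cc1` keeps the shared core and carries 4-methylphenyl in place of 2-fluorophenyl on an aromatic nitrogen of a five-membered aromatic ring with 3 nitrogen: 4-methylphenyl in place of 2-fluorophenyl on an aromatic nitrogen. Going by the values given here, no compound with a methyl group has been measured, so the evidence is indirect. The bearing steps are those that change the same aromatic group. Loss of the fluoro gives a 1.5-fold higher number from compound 2 to compound 3 (0.18 log units; within the scatter), and the largest step in the set, a 2.3-fold higher number from compound 1 to compound 3 (0.35 log units; beyond the scatter), is only modest. Going by these compounds, on that basis, no step beyond the scatter is expected in this assay, and the direction remains open. The estimated step is a 1.3-fold higher number from compound 2 to compound 4 (0.12 log units; within the scatter). For compound 4 the expected value is 80 nM, with an estimated range of 35 nM to 180 nM.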

Compound 4, half-maximal inhibitory concentration: 480 nM
The estimate for compound 4 lay 6.0-fold (0.78 log units) below the measured number, outside the stated range (above it).
By their numbers in this assay, from the lowest: compounds 1, 2 and 3 (each within the scatter of the next, the first and the last beyond it); then compound 4.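

In this assay, the aromatic group on the triazole nitrogen turns out to be far less forgiving than compounds 1 to 3 suggested: adding one methyl group to the phenyl ring gives a 5.3-fold higher number from compound 3 to compound 4 (0.73 log units; beyond the scatter). Going by these compounds alone, the exchanges for the other two aryl groups point the same way, with an 8.0-fold higher number from compound 2 to compound 4 (0.90 log units; beyond the scatter) and a 12-fold higher number from compound 1 to compound 4 (1.08 log units; beyond the scatter), the latter the only step in the set rated large. Nothing available explains why the 4-methylphenyl group stands so far from the other three.

The compounds shown leave open whether this weakening belongs to the methyl group itself or to the place it holds on the phenyl ring. They also leave open how a methoxy group or an amine would behave in place of that methyl.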